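Chain isomer step from compound 2 to compound 3

The compounds below may be only part of what the source reports. "The series", "measured", "known", "first", "only" and "open" are said of these compounds alone.

In a functional assay on A549 cells (Homo sapiens) for inhibition, read by MTT assay, with a stated time of 72 h (a higher number here means a weaker inhibitor, a lower number a stronger inhibitor), compound 1 `CC/C=C\C(=O)Nc1cc(Nc2nc3c(c(-c4cn(C)c5ccc(F)cc45)n2)CSCC3)c(OC)cc1N(C)CCN(C)C` gives 1450 nM and compound 2 `COc1cc(N(C)CCN(C)C)c(NC(=O)/C=C\C(C)C)cc1Nc1nc2c(c(-c3cn(C)c4ccc(F)cc34)n1)CSCC2` gives 1150 nM. Among the compounds with values here, compound 2 therefore stands level with compound 1, the only other measured compound, as the two values lie within the scatter of each other. Compound 3 `CCC/C=C\C(=O)Nc1cc(Nc2nc3c(c(-c4cn(C)c5ccc(F)cc45)n2)CSCC3)c(OC)cc1N(C)CCN(C)C` is next, with this change from compound 2: propyl in place of isopropyl on a double-bonded chain carbon bound to a double-bonded chain carbon. It has the same atoms, joined differently. Within the data shown here, the only measured step that bears on it is a 1.3-fold lower number from compound 1 to compound 2 (0.10 log units; within the scatter), which is methyl in place of hydrogen on a saturated chain carbon in the same chain. That step stays within the scatter, so no step beyond the scatter is expected in this assay. The estimated step is a 1.1-fold higher number from compound 2 to compound 3 (0.05 log units; within the scatter). For compound 3 the expected value is 1300 nM, with an estimated range of 650 nM to 2600 nM.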

Compound 3, half-maximal inhibitory concentration: 5190 nM
The estimate for compound 3 lay 4.0-fold (0.60 log units) below the measured number, outside the stated range (above it).
By their numbers in this assay, from the lowest: compounds 2 and 1 (each within the scatter of the next); then compound 3.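

In this assay, isopropyl and propyl are not interchangeable on the double-bonded chain carbon bound to a double-bonded chain carbon, although the two groups have the same atoms: the change gives a 4.5-fold higher number from compound 2 to compound 3 (0.65 log units; beyond the scatter). Methyl in place of hydrogen is also not equivalent at the two saturated chain carbons, since at the carbon two bonds along the chain from a double-bonded chain carbon it gives a 3.6-fold higher number from compound 1 to compound 3 (0.55 log units; beyond the scatter), while at the carbon bound to a double-bonded chain carbon it gives a 1.3-fold lower number from compound 1 to compound 2 (0.10 log units; within the scatter), which stays within the scatter. Nothing available explains this difference between the chains.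

The compounds shown leave open how a longer chain such as butyl, or a chain ending in a dimethylamino group, would read in this assay. They also leave open whether the gap between isopropyl and propyl would remain with the opposite double-bond geometry.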